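The source may hold more compounds than are shown below. What is called first, only, known or untested is meant among the compounds shown, and "the series" means these compounds.

Three compounds have been measured in an in vitro ADME assay on microsomes from liver (Homo sapiens) for pharmacokinetics, read by LC-MS, with a stated time of 10 min, tested at 1 uM; on this read-out lower numbers stand for slow clearance and higher numbers for fast clearance:

- Compound 1 `Cc1ccc(NC(=O)[C@H]2CN(C)C[C@@H]2c2ccc(/C=C/C(=O)Nc3ccccc3N)cc2)cc1` gives 15 mL/min/kg.
- Compound 2 `CN1C[C@H](C(=O)Nc2ccc(C(F)(F)F)cc2)[C@@H](c2ccc(/C=C/C(=O)Nc3ccccc3N)cc2)C1` gives 6 mL/min/kg.
- Compound 3 `Cc1cccc(NC(=O)[C@H]2CN(C)C[C@@H]2c2ccc(/C=C/C(=O)Nc3ccccc3N)cc2)c1` gives 14 mL/min/kg.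

Compound 3 stands second highest of the three numbers. Its nearest neighbour is compound 1, where a 1.1-fold lower number from compound 1 to compound 3 (0.03 log units; within the scatter), so these two cannot be told apart. Its furthest neighbour is compound 2, where a 2.3-fold higher number from compound 2 to compound 3 (0.37 log units; beyond the scatter).

Compound 4 `CN1C[C@H](C(=O)Nc2ccc(F)cc2F)[C@@H](c2ccc(/C=C/C(=O)Nc3ccccc3N)cc2)C1` has not yet been measured. It differs from compound 3 in one place: 2,4-difluorophenyl in place of 3-methylphenyl on an amide-type nitrogen. Two of the measured steps bear on this change, since both swap a methyl-bearing ring for a fluorine-bearing ring on the same amide-type nitrogen. In the first, a 2.5-fold lower number from compound 1 to compound 2 (0.40 log units; beyond the scatter). In the second, read in the reverse direction, a 2.3-fold higher number from compound 2 to compound 3 (0.37 log units; beyond the scatter), so the fluorine-bearing ring again sits on the lower number. Going by the values given here, on that basis a modest step downward in this assay is expected for compound 4, of about the size seen in those two steps, because a 2.5-fold lower number from compound 1 to compound 2 (0.40 log units; beyond the scatter) is the closest precedent. The expected step is a 1.8-fold lower number from compound 3 to compound 4 (0.24 log units; within the scatter). Compound 4 is therefore estimated at 8 mL/min/kg, within a range from 4 mL/min/kg to 16 mL/min/kg.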

Compound 4, clearance: 12 mL/min/kg
For compound 4 the middle estimate is 1.5-fold (0.18 log units) below the measured one, and the stated range covers the measured number.
By their numbers in this assay, from the lowest: compounds 2, 4, 3 and 1 (each within the scatter of the next, the first and the last beyond it).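

In this assay, the 2,4-difluorophenyl ring on the amide-type nitrogen cannot be told apart from either methylphenyl ring: there is a 1.2-fold lower number from compound 3 to compound 4 (0.07 log units; within the scatter) and a 1.3-fold lower number from compound 1 to compound 4 (0.10 log units; within the scatter). It also cannot be told apart from the 4-(trifluoromethyl)phenyl ring, with a 2.0-fold higher number from compound 2 to compound 4 (0.30 log units; within the scatter), so compound 4 is the only one of the four within the scatter of all the others, and carrying fluorine on this ring does not by itself put a compound clearly with compound 2 rather than with compound 1 and compound 3. Nothing shown here gives a reason for these numbers.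

The compounds shown leave open whether the two fluorines of compound 4 count equally, since neither a 2-fluorophenyl nor a 4-fluorophenyl ring is among them. They also leave open how this assay would respond if the ring on this nitrogen carried an amine or a carboxylic acid, or if a longer chain stood there in place of the aromatic ring.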